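The source may hold more compounds than are shown below. What is called first, only, known or untested is meant among the compounds shown, and "the series" means these compounds.

Measured so far in an assay on HEK293 cells for agonist activity at Toll-like receptor 8 (Homo sapiens), read by a luciferase reporter, with a stated time of 6 h; on this read-out lower numbers stand for an effect already at smaller amounts and higher numbers for an effect only at larger amounts of compound:
compound 1 `CCCCNc1nc(N)nc2c1CN(Cc1ccco1)CC2`: 0.08 uM
compound 2 `CCCCNc1nc(N)nc2c1CN(C(=O)CC)CC2`: 0.4 uM
compound 3 `CCCCNc1nc(N)nc2c1CN(C(=O)C1CCC1)CC2`: 0.4 uM

Compound 3 stands level with compound 2, the two together giving the highest numbers of the three; compound 1 sits apart, the step from it to either acyl compound being a 5.0-fold higher number from compound 1 to compound 3 (0.70 log units; beyond the scatter) and a 5.0-fold higher number from compound 1 to compound 2 (0.70 log units; beyond the scatter). The step within the acyl pair, no change at the digits printed from compound 2 to compound 3 (within the scatter), shows that the shape of the group on the carbonyl carbon made no difference between an ethyl and a cyclobutyl.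

Compound 4 `CCCCNc1nc(N)nc2c1CN(C(=O)c1cscn1)CC2` is the next member. Its change from compound 3 is 1,3-thiazol-4-yl in place of cyclobutyl on a carbonyl carbon. Within the data shown here, the only step that touches the same place is the one from compound 2 to compound 3, which was flat; the larger steps from compound 1 concern a different part of the group, the exchange of a methylene link for a carbonyl, and that carbonyl is kept here. Among the measured compounds shown here, no measured step covers an aromatic ring on the carbonyl carbon. The expectation for compound 4 is therefore a step of a 1.1-fold lower number from compound 3 to compound 4 (0.06 log units; within the scatter) in this assay, that is no move beyond the scatter, with room either way given the unknown. Compound 4 is estimated at 0.35 uM, expected between 0.1 uM and 1.2 uM.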

Compound 4, minimum effective concentration: 0.5 uM
Beside the measured number, compound 4's estimate is 1.4-fold (0.15 log units) below it; measured number inside the range.
By their numbers in this assay, from the lowest: compound 1; then compounds 2, 3 and 4 (each within the scatter of the next).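

In this assay an aromatic ring on the carbonyl carbon now comes into view, and 1,3-thiazol-4-yl in place of cyclobutyl gives a 1.3-fold higher number from compound 3 to compound 4 (0.10 log units; within the scatter) while in place of ethyl it gives a 1.3-fold higher number from compound 2 to compound 4 (0.10 log units; within the scatter), so the flat reading at this position now extends from the two carbon-only groups to a five-membered aromatic ring with hetero atoms. The separation from the (furan-2-yl)methyl compound persists with a 6.3-fold higher number from compound 1 to compound 4 (0.80 log units; beyond the scatter), which places compound 4 with compounds 2 and 3 as a third carbonyl-linked member on the far side of the scatter from compound 1. Nothing at hand accounts for this flatness.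

A phenyl, a longer chain or a carboxylic acid on the carbonyl carbon remains an open test of how far it extends. A (furan-2-yl)carbonyl group on the ring nitrogen would separate the contribution of the methylene link from that of the furan ring.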